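A few compounds are considered here, and "the series" means these few. Any claim that something is new, unique, unknown or untested is made for them only; others in the source may bear on it.

Working notes on the series.

The shared core carries an N-linked benzyl group on the pyrazole arm; two variants of that benzyl group have been measured. Compound 1 `CCCn1c(=O)c2nc(-c3cnn(Cc4cc(C(F)(F)F)ccc4Cl)c3)[nH]c2n(CCC)c1=O` gives 22 nM in an in vitro assay on HEK293 cells for displacement of a labelled ligand from adenosine receptor A2b (Homo sapiens); on this read-out higher numbers stand for weaker inhibition and lower numbers for stronger inhibition. For the measured compounds named here, compound 2 `CCCn1c(=O)c2nc(-c3cnn(Cc4c(F)cc(F)cc4F)c3)[nH]c2n(CCC)c1=O` gives 650 nM in this assay, the highest of the two numbers measured so far, with compound 1 as its only neighbour. Going by the values given here, the one step available, a 30-fold higher number from compound 1 to compound 2 (1.47 log units; beyond the scatter), shows that the pattern of substituents on the phenyl of the benzyl group moves this read-out a long way.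

Compound 3 `CCCn1c(=O)c2nc(-c3cnn(Cc4cccc(F)c4F)c3)[nH]c2n(CCC)c1=O` has not yet been measured in this assay. Its difference from compound 2 is 2,3-difluorophenyl in place of 2,4,6-trifluorophenyl on a saturated chain carbon bound to an aromatic nitrogen. Among the compounds with values here, no measured pair isolates this particular exchange; the only related step is the one from compound 1 to compound 2, which was large and went towards a higher number. Since compound 2 sits at the weak end of the measured range, a move back towards a lower number is expected, but its size is uncertain. For compound 3 a moderately lower number than compound 2 is estimated, a 2.6-fold lower number from compound 2 to compound 3 (0.41 log units; beyond the scatter), giving 250 nM with a range of 60 nM to 1500 nM.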

Compound 3, inhibition constant: 240 nM
For compound 3 the middle estimate is 1.0-fold (0.02 log units) above the measured one; the measured number falls inside the stated range.
By their numbers in this assay, from the lowest: compound 1; then compound 3; then compound 2.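

In this assay, 2,3-difluorophenyl in place of 2,4,6-trifluorophenyl gives a 2.7-fold lower number from compound 2 to compound 3 (0.43 log units; beyond the scatter), so the read-out responds to a change within the fluorinated phenyl groups and not only to the larger exchange seen earlier. The fluorine count and the fluorine pattern change together in this step, and it cannot be assigned to either one alone. The 2-chloro-5-(trifluoromethyl)phenyl group still holds a clear lead over both fluorinated groups, with an 11-fold higher number from compound 1 to compound 3 (1.04 log units; beyond the scatter), so the modest recovery in compound 3 leaves most of the earlier gap in place. Nothing at hand bears on the reason for these differences.

The compounds shown leave open whether the chlorine or the trifluoromethyl group accounts for the lower number of compound 1, as the two appear only together, on a single phenyl. Also open, as far as these compounds go, is how this position responds to an unsubstituted phenyl, a monofluorophenyl or a group of a different kind such as a methoxy group, an amine or a carboxylic acid on the phenyl.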